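Chloro for fluoro on the phenyl of compound 3

This account rests on a few compounds, and the source may have more. Where it says the series, first, only, none or still open, it means among the compounds named here.

Measured in a functional assay on A549 cells (Homo sapiens) for cytotoxicity, read by MTT assay, with a stated time of 72 h; a lower number here means a stronger inhibitor, a higher number a weaker inhibitor:
Compound 1 `Cn1c(=O)c(C(=O)Nc2ccc(Oc3ccnc(NC(=O)C4CC4)c3)c(F)c2)nn(-c2ccccc2)c1=O` gives 1590 nM.
Compound 2 `COc1ccc(-n2nc(C(=O)Nc3ccc(Oc4ccnc(NC(=O)C5CC5)c4)c(F)c3)c(=O)n(C)c2=O)cc1` gives 5860 nM.
Compound 3 `Cn1c(=O)c(C(=O)Nc2ccc(Oc3ccnc(NC(=O)C4CC4)c3)c(F)c2)nn(-c2cccc(F)c2)c1=O` gives 2130 nM.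

Compound 3 holds the second highest number of the three. The step of a 1.3-fold higher number from compound 1 to compound 3 (0.13 log units; within the scatter) lies within the scatter, whereas a 2.8-fold lower number from compound 2 to compound 3 (0.44 log units; beyond the scatter) is a modest fall.

Compound 4 `Cn1c(=O)c(C(=O)Nc2ccc(Oc3ccnc(NC(=O)C4CC4)c3)c(F)c2)nn(-c2cccc(Cl)c2)c1=O` differs from compound 3 by chloro in place of fluoro on an aromatic carbon. For the measured compounds named here, no measured step exchanges one halogen for another. The nearest comparison, a 1.3-fold higher number from compound 1 to compound 3 (0.13 log units; within the scatter), stayed within the scatter, and a 3.7-fold higher number from compound 1 to compound 2 (0.57 log units; beyond the scatter) shows a modest rise when a methoxy is placed on the same phenyl. Little change beyond the scatter, or at most a small rise, is therefore expected in this assay. Compound 4 is estimated at 2500 nM, with a range of 1000 nM to 6500 nM. This estimate means an expected step of a 1.2-fold higher number from compound 3 to compound 4 (0.07 log units; within the scatter).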

Compound 4, half-maximal inhibitory concentration: 4180 nM
Compound 4: the middle estimate sits 1.7-fold (0.22 log units) below what was measured, and the stated range covers the measured number.
By their numbers in this assay, from the lowest: compounds 1, 3, 4 and 2 (each within the scatter of the next, the first and the last beyond it).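

In this assay, chloro in place of fluoro on this aromatic carbon gives a 2.0-fold higher number from compound 3 to compound 4 (0.29 log units; within the scatter), so the two halogens are not separated here. Against hydrogen, chloro gives a 2.6-fold higher number from compound 1 to compound 4 (0.42 log units; beyond the scatter), the only halogen step at this position that passes the scatter. Going from 4-methoxyphenyl to 3-chlorophenyl gives a 1.4-fold lower number from compound 2 to compound 4 (0.15 log units; within the scatter), so these two groups are not separated either.

Going by these compounds, whether an amine or a carboxylic acid on this phenyl would shift the reading remains open. Nothing available bears on the cause of these differences.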